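The compounds below may be only part of what the source reports. "The series", "measured", "known", "first", "only" and "open" are said of these compounds alone.

Compound 3 `Cc1ccc(S(=O)(=O)N(CC(=O)NCc2ccc(Cl)cc2)c2ccc(C)nc2)cc1` stands in an assay on CHO cells for displacement of a labelled ligand from prostaglandin E2 receptor EP1 subtype (Homo sapiens) (a higher number here means a weaker inhibitor, a lower number a stronger inhibitor), only at a limit of the assay, < 1000 nM. Compound 1 `Cc1ccc(S(=O)(=O)N(CC(=O)NCc2ccc(Cl)cc2)c2cccnc2C)cc1` gives 200 nM in this assay, and compound 2 `Cc1ccc(S(=O)(=O)N(CC(=O)NCc2ccc(Cl)cc2)c2ncccc2C)cc1` gives 794 nM. Among the compounds with values here, the only readable step among the three is a 4.0-fold higher number from compound 1 to compound 2 (0.60 log units; beyond the scatter). The steps a step that the limit leaves unreadable from compound 1 to compound 3 and a step that the limit leaves unreadable from compound 2 to compound 3 stay unreadable, since compound 3 sits at the limit of < 1000 nM in this assay, at which 1 of the 3 values shown sits. Compound 4 `Cc1ccc(S(=O)(=O)N(CC(=O)NCc2ccc(Cl)cc2)c2cccc(C)n2)cc1` differs from compound 3 by 6-methylpyridin-2-yl in place of 6-methylpyridin-3-yl on a sulfonamide nitrogen. Like compound 2, compound 4 carries a pyridin-2-yl group on the sulfonamide nitrogen, so the closest guide is compound 2. Given that compound 2 gives 794 nM, compound 4 is expected near 700 nM, within 200 nM to 2500 nM. The expected step that the limit leaves unreadable from compound 3 to compound 4 is therefore likely to remain unreadable against the limit.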

Compound 4, inhibition constant: < 1000 nM
Compound 4: a limit, no number (the forecaster's own chance of this, stated with the estimate: 35%); the middle value lies beyond the limit too.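

Compound 4 gives < 1000 nM in this assay, a limit and not a number, so its steps to compound 1, compound 2 and compound 3 cannot be read: the limit of < 1000 nM in this assay, at which 2 of the 4 values shown sit.

On these data alone, the true standing of compound 3 and compound 4 against each other remains open.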